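Extending a para methyl to an ethyl in a weak series

This account rests on a few compounds, and the source may have more. Where it says the series, first, only, none or still open, it means among the compounds named here.

The measured compounds in a functional assay on U-87MG ATCC cells for inhibition, with U-87 MG (Homo sapiens) as the target, read by MTT assay, with a stated time of 72 h; on this read-out higher numbers stand for weaker inhibition and lower numbers for stronger inhibition:

Compound 1, `Oc1cccc(C(Nc2ccccn2)c2ccc3cccnc3c2O)c1Cl`, gives > 10000 nM, which is a limit of the assay and not a number.
Compound 2, `Cc1ccc(C)c(C(Nc2ccccn2)c2ccc3cccnc3c2O)c1`, gives 13800 nM.
Compound 3, `Cc1ccc(C(Nc2ccccn2)c2ccc3cccnc3c2O)cc1`, gives > 10000 nM, again a limit of the assay.

Compound 3 therefore stands at the limit of this assay, where (the limit of > 10000 nM in this assay, at which 2 of the 3 values shown sit). Compound 2 gives a number only slightly inside that limit, and the steps among these three compounds all remain unreadable: a step that the limit leaves unreadable from compound 1 to compound 2, a step that the two limits leave unreadable from compound 1 to compound 3 and a step that the limit leaves unreadable from compound 2 to compound 3 tell nothing about their size.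

Compound 4, `CCc1ccc(C(Nc2ccccn2)c2ccc3cccnc3c2O)cc1`, has not been measured. It differs from compound 3 by methyl in place of hydrogen on a saturated chain carbon bound to an aromatic carbon, so that methyl becomes ethyl and 4-methylphenyl becomes 4-ethylphenyl. No measured step changes this group, so nothing shown bears on the size or direction of the step. Compound 3 sits at the limit, and compound 4 is expected to stay near it, with an estimated step that the limit leaves unreadable from compound 3 to compound 4. Compound 4 is therefore estimated at 15000 nM, within 5000 nM to 50000 nM.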

Compound 4, half-maximal inhibitory concentration: 9300 nM
Beside the measured number, compound 4's estimate is 1.6-fold (0.21 log units) above it; the measured number falls inside the stated range.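

In this assay, extending methyl to ethyl gives an at least 1.0-fold lower number from compound 3 to compound 4 (0.03 log units; that floor lies within the scatter), so this change shows no loss of activity, though only a floor on the step can be read. Comparing 4-ethylphenyl with 2,5-dimethylphenyl gives a 1.5-fold lower number from compound 2 to compound 4 (0.17 log units; within the scatter), the first step in the series between two real numbers, and comparing it with 2-chloro-3-hydroxyphenyl gives an at least 1.0-fold lower number from compound 1 to compound 4 (0.03 log units; that floor lies within the scatter). None of these steps goes beyond the scatter, so the ethyl group does not set compound 4 apart from a series that still sits largely at the assay's limit: the limit of > 10000 nM in this assay, at which 2 of the 4 values shown sit.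

As far as these compounds go, the true size of the methyl-to-ethyl step remains unknown. Also open, from the compounds shown here alone, is whether a longer chain such as propyl, or an amine or a carboxylic acid on the same ring, would move the number clearly.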